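The compounds below may be only part of what the source reports. "The series", "measured", "known", "first", "only" and "open" are said of these compounds alone.

Compound 1 `COc1ccc2c(O[C@H]3C[C@H]4C(=O)N(C)CCCC/C=C/[C@@H]5C[C@@]5(C(=O)NS(=O)(=O)C5(C)CC5)NC(=O)N4C3)cc(-c3nc(C4CCC4)cs3)nc2c1Cl`: in an ADME assay on Huh-7 cells (Homo sapiens) for cytotoxicity, read by colorimetric assay (a higher number here means that more compound is tolerated, a lower number that less compound is tolerated), compound 1 gives 75000 nM.
Compound 2 `COc1ccc2c(O[C@H]3C[C@H]4C(=O)N(C)CCCC/C=C/[C@@H]5C[C@@]5(C(=O)NS(=O)(=O)C5(C)CC5)NC(=O)N4C3)cc(-c3csc(C(F)(F)F)n3)nc2c1Cl`: in this assay compound 2 gives 59000 nM.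

Compound 2 and compound 1 lie within the scatter of each other, as the step of a 1.3-fold lower number from compound 1 to compound 2 (0.10 log units; within the scatter) shows. Compound 3 `COc1ccc2c(O[C@H]3C[C@H]4C(=O)N(C)CCCC/C=C/[C@@H]5C[C@@]5(C(=O)NS(=O)(=O)C5(C)CC5)NC(=O)N4C3)cc(-n3cc(C(F)(F)F)cn3)nc2c1Cl` carries 4-(trifluoromethyl)-1H-pyrazol-1-yl in place of 2-(trifluoromethyl)-1,3-thiazol-4-yl on an aromatic carbon. For the measured compounds named here, the only measured step that bears on this change is the one from compound 1 to compound 2, a swap of one five-membered heteroaryl for another at the same place, and it stayed within the scatter. No step beyond the scatter is therefore expected in this assay for compound 3, whose value is estimated at 60000 nM (range 30000 nM to 120000 nM), a step of a 1.0-fold higher number from compound 2 to compound 3 (0.01 log units; within the scatter).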

Compound 3, half-maximal cytotoxic concentration: 21900 nM
Beside the measured number, compound 3's estimate is 2.7-fold (0.44 log units) above it; measured number outside the range, below it.
By their numbers in this assay, from the lowest: compound 3; then compounds 2 and 1 (each within the scatter of the next).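

Replacing 2-(trifluoromethyl)-1,3-thiazol-4-yl with 4-(trifluoromethyl)-1H-pyrazol-1-yl gives a 2.7-fold lower number from compound 2 to compound 3 (0.43 log units; beyond the scatter) in this assay, so this place, next to the ring nitrogen, is not indifferent to which five-membered aromatic ring it carries, although the first swap stayed within the scatter. Against the 4-cyclobutyl-1,3-thiazol-2-yl group, the step is also beyond the scatter: a 3.4-fold lower number from compound 1 to compound 3 (0.53 log units; beyond the scatter). Nothing available explains this difference. The compounds shown leave open whether a pyrazole joined through a ring carbon would behave like compound 3. They also leave open how an amine or a carboxylic acid at this place would read in this assay.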